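Hydrogen for phenyl on the fused core: stability estimate

The source may hold more compounds than are shown below. What is called first, only, known or untested is meant among the compounds shown, and "the series" means these compounds.

Measured so far in an ADME assay on microsomes from liver (Homo sapiens) for metabolic stability; a lower number here means that the compound disappears faster, a higher number that the compound lasts longer:
- compound 1 `CCCNC(=O)C1CCN(C(=O)c2cc3sc(-c4ccccc4)nc3n2Cc2ccc(OC)cc2)CC1`: 0.68 h
- compound 2 `CCCNC(=O)C1CCN(C(=O)c2cc3sc(C)cc3n2Cc2ccc(OC)cc2)CC1`: 0.0448 h
- compound 3 `CCCNC(=O)C1CC12CCN(C(=O)c1cc3sc(Br)nc3n1Cc1ccc(OC)cc1)CC2`: 0.0828 h

Compound 1 holds the highest number of the three in this assay. Compound 3 comes nearest, with a number well beyond the scatter below it, and compound 2 lies furthest, also beyond the scatter. Within the data shown here, compounds 2 and 3 each differ from compound 1 in more than one place, so no single step between measured compounds is available.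

The next compound, compound 4 `CCCNC(=O)C1CCN(C(=O)c2cc3scnc3n2Cc2ccc(OC)cc2)CC1`, differs from compound 1 in one place: hydrogen in place of phenyl on an aromatic carbon. Both compounds that lack phenyl on the core show lower numbers than compound 1, but neither is a clean comparison.

A decrease beyond the scatter is expected from compound 1 to compound 4, a 3.4-fold lower number from compound 1 to compound 4 (0.53 log units; beyond the scatter), because compound 1 with its 0.68 h stands apart from compounds 2 and 3. Compound 4 is estimated at 0.2 h in this assay, within a range from 0.06 h to 0.6 h.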

Compound 4, half-life: 0.462 h
For compound 4 the middle estimate is 2.3-fold (0.36 log units) below the measured one, and the stated range covers the measured number.
By their numbers in this assay, from the lowest: compounds 2 and 3 (each within the scatter of the next); then compounds 4 and 1 (each within the scatter of the next).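

In this assay, hydrogen in place of phenyl on this aromatic carbon gives a 1.5-fold lower number from compound 1 to compound 4 (0.17 log units; within the scatter), so this position, next to the ring nitrogen and the ring sulfur, does not separate the two groups in this read-out. Among these compounds, compounds 2 and 3 could not show this, since each differs from compound 1 in more than one place, and only this single step isolates the position. Nothing available here bears on why the two groups are not separated.

Open, on these data alone, is how this carbon behaves with a group of another kind, such as an amine, a carboxylic acid or a longer alkyl chain, since only phenyl and hydrogen can be compared directly here. Also open, as far as these compounds go, is whether the same step would read alike with a different group in place of the propyl amide.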